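Cyclopropyloxy for phenoxy in a nitroimidazooxazine series

The source may report more compounds than this note shows. Statements on the series, on what has been measured and on what is new or still open speak of the compounds shown alone.

Of the compounds shown here, three of a shared core have been measured in a physicochemical assay for solubility, at pH 6.8; a lower number here means a less soluble compound, a higher number a more soluble compound. Compound 1 `CCCN(Cc1ccc(OC(F)(F)F)cc1)[C@@H]1COc2nc([N+](=O)[O-])cn2C1` returns only a limit, < 2 ug/mL, in this assay; this is the case described by the limit of < 2 ug/mL in this assay, at which 1 of the 3 values shown sits. Compound 2 `O=[N+]([O-])c1cn2c(n1)OC[C@@H](NCc1ccc(OC(F)(F)F)cc1Cl)C2` gives 30 ug/mL in this assay, and compound 3 `O=[N+]([O-])c1cn2c(n1)OC[C@@H](NCc1ccc(OC(F)(F)F)cc1Oc1ccccc1)C2` gives 3 ug/mL. Among the compounds with values here, the single measured step, phenoxy in place of chloro on an aromatic carbon, reads a 10-fold lower number from compound 2 to compound 3 (1.00 log units; beyond the scatter), so compound 3 stands lowest of the two numbers, with compound 2 its nearest neighbour a full step higher.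

Compound 4 `O=[N+]([O-])c1cn2c(n1)OC[C@@H](NCc1ccc(OC(F)(F)F)cc1OC1CC1)C2` differs from compound 3 by cyclopropyl in place of phenyl on an oxygen on an aromatic ring. The step from compound 2 to compound 3 is the only one that bears on this change, since it shows what the phenoxy group did to the number; removing the phenyl in favour of cyclopropyl is expected to recover part of that drop rather than all of it. Compound 4 is therefore expected to give 8 ug/mL in this assay, within 3 ug/mL to 25 ug/mL, which means an expected step of a 2.7-fold higher number from compound 3 to compound 4 (0.43 log units; beyond the scatter).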

Compound 4, solubility: 11 ug/mL
Beside the measured number, compound 4's estimate is 1.4-fold (0.14 log units) below it, and the stated range covers the measured number.
By their numbers in this assay, from the lowest: compound 3; then compound 4; then compound 2. At a limit, below all of these: compound 1.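

With the oxygen kept in place, the reading in this assay is a 3.7-fold higher number from compound 3 to compound 4 (0.56 log units; beyond the scatter) when cyclopropyl replaces phenyl, so the number responds to the group carried on that oxygen and not only to the change from chloro to an oxygen-linked group. Even so, the reading is a 2.7-fold lower number from compound 2 to compound 4 (0.44 log units; beyond the scatter) when cyclopropyloxy stands in place of chloro, so the return towards the chloro compound is only partial. None of the measurements shown accounts for either step.

On these data alone, whether an open-chain ether such as methoxy or ethoxy on this aromatic carbon would match compound 2 or fall nearer compound 4 remains open. So does the reading for a group of another kind in that place, such as an amine or a carboxylic acid.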